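This account rests on a few compounds, and the source may have more. Where it says the series, first, only, none or still open, it means among the compounds named here.

Compound 1, `CCOC(=O)c1c(C)nc(-c2cccc(C#N)c2)n1OCc1ccc(C)cc1`, gives 6310 nM in a functional assay on a cell-free system (plasma, Oryctolagus cuniculus) for inhibition, with stated times of 5 min, 1 min and 6 min; on this read-out lower numbers stand for stronger inhibition and higher numbers for weaker inhibition.
Compound 2, `CCOC(=O)c1c(C)nc(-c2cccc(C#N)c2)n1OCc1ccc(C#N)cc1`, gives 4240 nM in this assay.
Compound 3, `Cc1ccc(COn2c(-c3cccc(C#N)c3)nc(C)c2C(=O)O)cc1`, gives 6560 nM in this assay.

Of the compounds shown here, three have been measured, and they share a common core carrying a benzyl group on one side and an ester or acid on the other. Within the data shown here, the first change to consider is cyano in place of methyl on an aromatic carbon. Made on the ester core, it gives a 1.5-fold lower number from compound 1 to compound 2 (0.17 log units; within the scatter), so the two ester compounds cannot be told apart on this read-out.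

The second change, (hydrogen in place of ethyl on an oxygen next to a carbonyl group), separates the two cores. It gives a 1.0-fold higher number from compound 1 to compound 3 (0.02 log units; within the scatter), so the ester and the acid behave alike as well.

Compound 4, `Cc1nc(-c2cccc(C#N)c2)n(OCc2ccc(C#N)cc2)c1C(=O)O`, has not yet been measured. It differs from compound 3 by cyano in place of methyl on an aromatic carbon. Among the measured compounds shown here, the surroundings of the changed position are described in the same words for both pairs, so this is the same change as the one from compound 1 to compound 2, now made on the acid core instead of the ester core. Since the change made almost no difference on the ester core, and since the cores themselves stand close together, a step of about the same size is expected from compound 3 to compound 4, namely a 1.5-fold lower number from compound 3 to compound 4 (0.17 log units; within the scatter). Compound 4 is therefore expected to give 4400 nM in this assay, with a range from 2200 nM to 8800 nM.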

Compound 4, half-maximal inhibitory concentration: 3880 nM
Beside the measured number, compound 4's estimate is 1.1-fold (0.05 log units) above it; measured number inside the range.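

On the acid core, cyano in place of methyl gives a 1.7-fold lower number from compound 3 to compound 4 (0.23 log units; within the scatter), and this step agrees with the one seen on the ester core in this assay: the same change on two cores in this assay, a 1.5-fold lower number (0.17 log units; within the scatter) from compound 1 to compound 2 and a 1.7-fold lower number (0.23 log units; within the scatter) from compound 3 to compound 4, 1.1-fold (0.06 log units) apart, within the scatter of two such steps
The other change, hydrogen in place of ethyl, gives a 1.1-fold lower number from compound 2 to compound 4 (0.04 log units; within the scatter) among the compounds carrying the 4-cyanobenzyl group, and it also agrees with its earlier counterpart: the same change on two cores in this assay, a 1.0-fold higher number (0.02 log units; within the scatter) from compound 1 to compound 3 and a 1.1-fold lower number (0.04 log units; within the scatter) from compound 2 to compound 4, 1.1-fold (0.06 log units) apart, within the scatter of two such steps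
Within these four compounds, then, each change has a step of about the same size on both cores, but all of these steps lie within the scatter, so what carries over is only the lack of a clear effect; this does not show that a change with a clear effect would carry over in the same way.

The compounds shown leave open whether any group at these two places can shift the number beyond the scatter, for example a chlorine or a methoxy group in the place held by methyl and cyano, or an amide in place of the ester and the carboxylic acid. If such a group gave a clear step, it would remain to be seen whether that step keeps its size from one core to the other.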